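Working notes: compound 3 against the two measured compounds

The source may report more compounds than this note shows. Statements on the series, on what has been measured and on what is new or still open speak of the compounds shown alone.

Measured so far in a functional assay on MCF7 cells (Homo sapiens) for inhibition, read by CCK-8 assay, with a stated time of 48 h; a lower number here means a stronger inhibitor, a higher number a weaker inhibitor:
compound 1 `COc1cc(-c2ccnc3cc(-c4ccc5cc[nH]c5c4)nn23)cc(OC)c1OC` gives 23 nM
compound 2 `COc1cc(-c2ccnc3cc(-c4ccc5ccn(C)c5c4)nn23)cc(OC)c1OC` gives 74 nM

Compound 2 stands highest of the two numbers in this assay. Going by the values given here, the only step measured, a 3.2-fold higher number from compound 1 to compound 2 (0.51 log units; beyond the scatter), is beyond the scatter and modest in size.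

Compound 3 `COc1cc(-c2ccnc3cc(-c4ccc(C(C)(C)C)cc4)nn23)cc(OC)c1OC` differs from compound 2 by 4-(tert-butyl)phenyl in place of 1-methyl-1H-indol-6-yl on an aromatic carbon.

Among the compounds with values here, no measured step covers this exchange. Within the data shown here, the single step known concerns a methyl on an aromatic nitrogen inside the group that leaves, and it cannot be carried over to an exchange of the whole group. It does show that this position answers to a small change with a shift beyond the scatter; the present exchange is far larger and removes the ring nitrogen entirely, so a larger shift is plausible, with direction uncertain. On balance compound 3 is expected to come out a weaker inhibitor than compound 2, by about a 2.4-fold higher number from compound 2 to compound 3 (0.39 log units; beyond the scatter), with a wide range. The estimate for compound 3 in this assay is 180 nM, between 40 nM and 800 nM.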

Compound 3, half-maximal inhibitory concentration: > 10000 nM
Compound 3 was reported as a limit (the forecaster's own chance of this, stated with the estimate: 5%); middle value at least 55-fold (1.74 log units) away from the limit.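

Compound 3 is reported only as a limit, not a number, in this assay: the limit of > 10000 nM in this assay, at which 1 of the 3 values shown sits.

The earlier compounds shown here showed only a modest response at this position, with a 3.2-fold higher number from compound 1 to compound 2 (0.51 log units; beyond the scatter) for a methyl on the aromatic nitrogen, whereas exchanging the whole group gives a far larger loss: an at least 130-fold higher number from compound 2 to compound 3 (2.13 log units; beyond the scatter), and an at least 430-fold higher number from compound 1 to compound 3 (2.63 log units; beyond the scatter). The leaving and entering groups have the same count of heavy atoms, so that count does not separate the active compounds from compound 3; what differs is that 4-(tert-butyl)phenyl has one aromatic ring and no nitrogen, where each indolyl group has a five-membered aromatic ring with a hetero atom fused to a six-membered one.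

The three compounds do not show whether the loss follows from removing the five-membered ring, removing the ring nitrogen or adding the tert-butyl group, since all three changes arrive together in compound 3. An unsubstituted phenyl, or a phenyl carrying an amine or a methoxy group in place of tert-butyl, would begin to separate these changes.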